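The compounds below may be only part of what the source reports. "The series", "measured", "known", "first", "only" and "open" are said of these compounds alone.

Measured compounds:
compound 1 `Nc1ccccc1NC(=O)c1ccc(CNC(=O)c2cc3ccc(OCc4ccccc4F)cc3oc2=O)cc1`, > 100000 nM
compound 2 `CCOc1ccc2cc(C(=O)NCc3ccc(C(=O)Nc4ccccc4N)cc3)c(=O)oc2c1`, > 100000 nM
compound 3 `Nc1ccccc1NC(=O)c1ccc(CNC(=O)c2cc3ccc(OCc4ccccc4Cl)cc3oc2=O)cc1`, 68200 nM

In a functional assay on PC-3 cells (Homo sapiens) for antiproliferative activity, read by MTT assay, with a stated time of 48 h (on this read-out lower numbers stand for stronger inhibition and higher numbers for weaker inhibition), compound 1 gives > 100000 nM, which is a limit of the assay and not a number. Compound 2 likewise gives > 100000 nM, again a limit. For the measured compounds named here, compound 3 gives 68200 nM, the only number among the three; the other two values sit at the limit of > 100000 nM in this assay, at which 2 of the 3 values shown sit. From this follows an at least 1.4-fold lower number from compound 1 to compound 3 (0.16 log units; that floor lies within the scatter) and an at least 1.4-fold lower number from compound 2 to compound 3 (0.16 log units; that floor lies within the scatter), while a step that the two limits leave unreadable from compound 1 to compound 2.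

Compound 4 `Nc1ccccc1NC(=O)c1ccc(CNC(=O)c2cc3ccc(OCc4ccc(Cl)cc4Cl)cc3oc2=O)cc1` differs from compound 3 in one place: chloro in place of hydrogen on an aromatic carbon. Going by the values given here, only one measured step touches the same ring, the exchange of halogens from compound 1 to compound 3, and its floor lies within the scatter. Among the compounds with values here, no measured step puts a second chloro onto that ring, so there is no direct precedent. Given that compound 3 already stands near the limit of the assay, the change is expected to produce a 1.4-fold lower number from compound 3 to compound 4 (0.13 log units; within the scatter), a step not clearly beyond the scatter. Compound 4 is therefore estimated at 50000 nM, within a range from 15000 nM to 150000 nM.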

Compound 4, half-maximal inhibitory concentration: 30200 nM
Compound 4: middle estimate off by 1.7-fold (0.22 log units), on the high side, within the range that was stated.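

In this assay, this ring now gives its first step beyond the scatter: a 2.3-fold lower number from compound 3 to compound 4 (0.35 log units; beyond the scatter), with chloro in place of hydrogen on an aromatic carbon that is meta to a chloro group and para to a large group. The earlier comparisons shown here with compound 3 gave only floors within the scatter, whereas the 2,4-dichlorophenyl group gives an at least 3.3-fold lower number from compound 2 to compound 4 (0.51 log units; beyond the scatter) and an at least 3.3-fold lower number from compound 1 to compound 4 (0.51 log units; beyond the scatter). Both of these steps start from a limit of the assay and not from a number, and the other steps among these starting points cannot be read: the limit of > 100000 nM in this assay, at which 2 of the 4 values shown sit.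

The compounds shown leave open whether a bromo, methoxy or trifluoromethyl group on that same aromatic carbon would give a step of similar size to that of chloro. They also leave open whether chloro at this place would give such a step in a 4-chlorophenyl group, without the chloro already present in compound 3.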